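Phenyl in place of (but-2-yn-1-yl)oxy: an expected step

The compounds below may be only part of what the source reports. "The series", "measured", "known", "first", "only" and "open" are said of these compounds alone.

Values so far in a physicochemical assay for lipophilicity; a higher number here means a more lipophilic compound, a lower number a more polar compound
- compound 1 `C#CC[C@H](NC(=O)c1ccccc1)C(=O)NO` gives 0.61
- compound 2 `C#CC[C@H](NC(=O)c1ccc(OCC#CC)cc1)C(=O)NO` gives 1.29

Compound 2 holds the higher of the two numbers. The next structure is compound 3 `C#CC[C@H](NC(=O)c1ccc(-c2ccccc2)cc1)C(=O)NO` with phenyl in place of (but-2-yn-1-yl)oxy on an aromatic carbon, counted as phenyl in place of (but-2-yn-1-yl)oxy on an aromatic carbon in full. Within the data shown here, only one measured step bears on this change: a number 0.68 log units higher from compound 1 to compound 2 (beyond the scatter) is modest and beyond the scatter, and it concerns (but-2-yn-1-yl)oxy in place of hydrogen. Among the measured compounds shown here, no measured step involves phenyl, so a further modest rise in this assay is only tentatively expected. The estimated change is a number 0.51 log units higher from compound 2 to compound 3 (beyond the scatter) in size. Compound 3 is estimated at 1.8 within a range of 1.35 to 2.3 for the coming measurement.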

Compound 3, partition coefficient: 2.28
For compound 3 the middle estimate is 0.48 log units below the measured one; low and high end bracket the measured number.
By their numbers in this assay, from the lowest: compound 1; then compound 2; then compound 3.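

In this assay, phenyl on this aromatic carbon gives a number 1.67 log units higher from compound 1 to compound 3 (beyond the scatter) and so exceeds the rise seen with (but-2-yn-1-yl)oxy. Exchanging the two substituents directly gives a number 0.99 log units higher from compound 2 to compound 3 (beyond the scatter), which shows that the number at this position depends strongly on which group is present, not merely on replacing hydrogen. Nothing available explains why phenyl gives the higher number. On these data alone, whether an amine or a carboxylic acid on this aromatic carbon would bring the number back towards that of the unsubstituted compound 1 remains open.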